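A few compounds are considered here, and "the series" means these few. Any claim that something is new, unique, unknown or untested is made for them only; others in the source may bear on it.

In an ADME assay on HFF cells (Homo sapiens) for cytotoxicity, with a stated time of 8 days (a higher number here means that more compound is tolerated, a lower number that less compound is tolerated), compound 1 `CCCCCCCCOc1nc(N)nc2c1ncn2/C=C1/CC1(CO)CO`, which carries an octyloxy group, returns only a limit of the assay, > 300000 nM, and not a number. Compound 2 `Nc1nc(OCc2ccccc2)c2ncn(/C=C3/CC3(CO)CO)c2n1` also returns only a limit, > 300000 nM. Compound 3 `Nc1nc2c(ncn2/C=C2/CC2(CO)CO)c(=O)[nH]1` likewise returns only a limit, > 300000 nM. The whole picture so far is therefore (the limit of > 300000 nM in this assay, at which 3 of the 3 values shown sit), so compound 1 cannot be ranked against the others.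

Compound 4 `Nc1nc(N2CCCC2)c2ncn(/C=C3/CC3(CO)CO)c2n1` has pyrrolidin-1-yl in place of octyloxy on an aromatic carbon of the shared core: pyrrolidin-1-yl in place of octyloxy on an aromatic carbon. The nearest measured change is a step that the two limits leave unreadable from compound 1 to compound 2, with phenyl in place of heptyl, and it gives no size to carry over. Among the compounds with values here, no measured step shows any loss of tolerance, though limits cannot rule one out. On the strength of the limit of > 300000 nM in this assay, at which 3 of the 3 values shown sit, no change beyond the scatter is expected in this assay. The expected change is a number no higher from compound 1 to compound 4 (the limit leaves the size open). Compound 4 is estimated at 300000 nM, with an expected range from 100000 nM to 300000 nM.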

Compound 4, half-maximal cytotoxic concentration: > 300000 nM
Compound 4 was reported as a limit; the forecaster's own chance of this, stated with the estimate: 80%; the middle value sits exactly at the limit.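

Compound 4 returns only a limit, as do compound 1 and compound 2, so neither step to compound 4 can be read. The compounds shown leave open at what concentration any of them becomes toxic in this assay, and whether swapping these groups changes that concentration: the limit of > 300000 nM in this assay, at which 4 of the 4 values shown sit.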